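The source may report more compounds than this note shows. Statements on the series, on what has been measured and on what is new or still open speak of the compounds shown alone.

Within the data shown here, in a functional assay on SGC-7901 cells (Homo sapiens) for antiproliferative activity, read by MTT assay, with a stated time of 72 h (a lower number here means a stronger inhibitor, a higher number a weaker inhibitor), compound 2 `COc1cc(-n2cnc3ccc(-c4ccc(C)cc4)cc32)cc(OC)c1OC` gives 200 nM as the higher of the two numbers measured so far, while compound 1 `COc1ccc(-c2ccc3ncn(-c4cc(OC)c(OC)c(OC)c4)c3c2)cc1O` gives 44 nM as the lower one. Among the measured compounds shown here, the only measured step is a 4.5-fold higher number from compound 1 to compound 2 (0.66 log units; beyond the scatter) and it puts 4-methylphenyl in place of 3-hydroxy-4-methoxyphenyl on an aromatic carbon. Compound 3 `COc1ccc(-c2ccc3ncn(-c4cc(OC)c(OC)c(OC)c4)c3c2)cc1` differs from compound 2 in one place, namely methoxy in place of methyl on an aromatic carbon with methoxy in place of methyl on an aromatic carbon, para to a large group. The result is 4-methoxyphenyl, which shares its methoxy with compound 1 but has no hydroxy. Compound 3 is therefore expected to win back only part of a 4.5-fold higher number from compound 1 to compound 2 (0.66 log units; beyond the scatter) in this assay as a modest move toward a lower number. The estimated move is a 2.0-fold lower number from compound 2 to compound 3 (0.30 log units; within the scatter) and it may barely clear the usual scatter. For compound 3 the estimated value is 100 nM with an expected range of 35 nM to 280 nM for repeated measurements.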

Compound 3, half-maximal inhibitory concentration: 82 nM
Estimate against measurement, compound 3: 1.2-fold (0.09 log units) above, within the range that was stated.
By their numbers in this assay, from the lowest: compounds 1 and 3 (each within the scatter of the next); then compound 2.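

In this assay, the change from 4-methylphenyl to 4-methoxyphenyl gives a 2.4-fold lower number from compound 2 to compound 3 (0.39 log units; beyond the scatter), so at this place, para to a large group, methoxy is enough for a step beyond the scatter with no hydroxy present. Putting hydrogen in place of the hydroxy gives a 1.9-fold higher number from compound 1 to compound 3 (0.27 log units; within the scatter), so the earlier step, a 4.5-fold higher number from compound 1 to compound 2 (0.66 log units; beyond the scatter), can be read mainly as the loss of the methoxy, and the hydroxy adds nothing that can be told apart from the scatter. No measurement at hand explains why methoxy and methyl differ here.

Still open, from the compounds shown here alone, is whether ethoxy, a longer ether chain or an amine at the same place would hold the number as low. Also open, going by these compounds, is how a ring carrying hydroxy alone, without methoxy, would compare.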